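A few compounds are considered here, and "the series" means these few. Any claim that something is new, unique, unknown or untested is made for them only; others in the source may bear on it.

Compounds measured so far in a functional assay on MCF7 cells (Homo sapiens) for cytotoxicity, read by MTT assay; on this read-out higher numbers stand for weaker inhibition and lower numbers for stronger inhibition:
- compound 1, `CCCCCCCCCC(O)CN`: 3880 nM
- compound 2, `COC(=O)CCCCCCCCC(O)CN`: 10200 nM
- compound 3, `NCC(O)CCCCCCCCC(=O)O`: "not active" (no number reported)

Compound 3 has no number in this assay; it was reported as not active, so its place among the others can only be described as weaker than any value that was recorded. Compound 4, `NCC(O)CCCCCCCCCO`, differs from it by one change: hydroxymethyl in place of carboxy on a saturated chain carbon, nine bonds along the chain from an oxygen on a saturated carbon.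

Within the data shown here, only one measured step touches the same chain position. There the change was methoxycarbonyl in place of methyl, and it gave a 2.6-fold higher number from compound 1 to compound 2 (0.42 log units; beyond the scatter), a modest loss. Compound 2 and compound 3 together suggest that a carbonyl-bearing group at this end of the chain is unfavourable, with the free acid worst of all. Hydroxymethyl carries no carbonyl, so compound 4 is expected to return toward the range set by compound 1 and compound 2 rather than stay inactive, though the data give no direct precedent for this exact swap. For compound 4 the estimate in this assay is 8000 nM, with a plausible range from 2500 nM to 40000 nM.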

Compound 4, half-maximal inhibitory concentration: "not active" (no number reported)
Compound 4: no number reported; no gap can be computed for the estimate.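

In this assay compound 3 and compound 4 were both reported as not active, with no number for either, so no step can be read between them. No evidence bears on this result. The compounds shown leave open whether carboxy and hydroxymethyl differ at all at this chain end.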